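Taking the bromoethenyl carbonyl off compound 2

The source may hold more compounds than are shown below. What is called first, only, known or untested is meant among the compounds shown, and "the series" means these compounds.

In a functional assay on FM3A cells (Mus musculus) for antiproliferative activity, with a stated time of 48 h (on this read-out higher numbers stand for weaker inhibition and lower numbers for stronger inhibition), compound 1 (`C=C(Br)C(=O)Nc1ccc(C(=O)/C=C/c2ccc(OC)cc2)cc1`) gives 1000 nM and compound 2 (`C=C(Br)C(=O)Nc1ccc(C(=O)/C=C/c2ccc(N(C)C)cc2)cc1`) gives 2800 nM as the higher of the two numbers. Compound 3 (`CN(C)c1ccc(/C=C/C(=O)c2ccc(N)cc2)cc1`) has hydrogen in place of (1-bromoethenyl)carbonyl on a nitrogen on an aromatic ring of compound 2 (hydrogen in place of (1-bromoethenyl)carbonyl on a nitrogen on an aromatic ring). Among the compounds with values here, the only measured step (a 2.8-fold higher number from compound 1 to compound 2 (0.45 log units; beyond the scatter)) is modest and lies elsewhere in the molecule, and no measured compound lacks this group, so that step bears only indirectly. In this assay a clear rise in the number is nonetheless expected (a 5.4-fold higher number from compound 2 to compound 3 (0.73 log units; beyond the scatter)). Compound 3 is estimated at 15000 nM with an expected range of 5000 nM to 50000 nM for its measurement.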

Compound 3, half-maximal inhibitory concentration: 96000 nM
The estimate for compound 3 lay 6.4-fold (0.81 log units) below the measured number, and the stated range ends below it.
By their numbers in this assay, from the lowest: compound 1; then compound 2; then compound 3.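

In this assay, removing the (1-bromoethenyl)carbonyl from the nitrogen on the aromatic ring weakens inhibition substantially, giving a 34-fold higher number from compound 2 to compound 3 (1.54 log units; beyond the scatter). Within the data shown here, this is the first measured change at this position, and it shows that the free amino compound loses much of the inhibition seen with the acylated nitrogen, at least with dimethylamino on the other side of the molecule. No measurement here explains the loss.

Going by these compounds, it remains open whether the bromine, the double bond or the carbonyl accounts for the step. An acetyl group on that nitrogen could help separate them, and the same removal from compound 1 would test whether the effect holds with methoxy.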